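Replacing one fluorine with hydrogen on a fluorinated benzoate core

This account rests on a few compounds, and the source may have more. Where it says the series, first, only, none or still open, it means among the compounds named here.

In a toxicity assay on the whole organism (strain CD-1) for cytotoxicity, with Mus musculus as the target, with a stated time of 14 days, at a dose of 150 mg/kg by the intraperitoneal route (on this read-out higher numbers stand for a weaker effect at the one dose given and lower numbers for a stronger effect), compound 1 `COC(=O)c1c(O)c(F)c(F)c(F)c1F` gives 90%. Compound 2 `COC(=O)c1cc(F)c(F)c(F)c1O` differs from compound 1 by hydrogen in place of fluoro on an aromatic carbon. In this assay compound 2 gives 100%; the step of a number 10 percentage points higher from compound 1 to compound 2 (within the scatter). Compound 3 `CC(=O)Oc1c(C(=O)O)cc(F)c(F)c1F` has a core that differs from that of compound 1 in more than one place; that difference between the two cores is not broken down here. In this assay compound 3 gives 70%, a number that lies below those of compound 1 and compound 2 by more than the usual scatter.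

Compound 4 `CC(=O)Oc1cc(F)c(F)cc1C(=O)O` differs from compound 3 by hydrogen in place of fluoro on an aromatic carbon. Among the compounds with values here, this is the same kind of change as the one from compound 1 to compound 2, but the surroundings differ: here the place is ortho to an acetoxy group and meta to a carboxy group, whereas in compound 1 it was ortho to a methoxycarbonyl group, meta to a hydroxy group and para to a fluoro group. Because the step of a number 10 percentage points higher from compound 1 to compound 2 (within the scatter), compound 4 is expected to show a step of about a number 10 percentage points higher from compound 3 to compound 4 (within the scatter) in this assay. The estimate for compound 4 in this assay is 80%, with a likely range from 65% to 95%.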

Compound 4, a percentage reported as activity, at one dose (the size of the read-out at that dose, not a potency): 100%
Beside the measured number, compound 4's estimate is 20 percentage points below it, and the stated range ends below it.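

On the core of compound 3, hydrogen in place of fluoro on an aromatic carbon gives a number 30 percentage points higher from compound 3 to compound 4 (beyond the scatter) in this assay. Set beside the earlier case, the same change does not carry over from one core to the other as a fixed amount: the same change on two cores in this assay, a number 10 percentage points higher (within the scatter) from compound 1 to compound 2 and a number 30 percentage points higher (beyond the scatter) from compound 3 to compound 4, 20 percentage points apart, beyond the scatter of two such steps

Two pairs do not show why the steps differ: the cores differ in more than one place and the changed carbon has different surroundings on each, so no single feature can be named as the reason, and no rule follows for other cores in this series.

The compounds shown put only hydrogen where the fluoro group stood, which leaves open what an amine, a chlorine atom or a methoxy group at that place would do in this assay. Also open, going by these compounds, is what size of step the same change would give on a core with a longer chain in place of the acetoxy group.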